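Aryl ester variation on a shared core: outlook for compound 4

A few compounds are considered here, and "the series" means these few. Any claim that something is new, unique, unknown or untested is made for them only; others in the source may bear on it.

compound 1 `COc1ccc(C(=O)Oc2cc3c(cc2C)[C@@H](C(C)C)CC=C3C)cc1` — 80.1%
compound 2 `CC1=CC[C@H](C(C)C)c2cc(C)c(OC(=O)c3cccc(C)c3)cc21` — 54.9%
compound 3 `CC1=CC[C@H](C(C)C)c2cc(C)c(OC(=O)c3ccc(Cl)cc3)cc21` — 79.7%

All three were read in a functional assay on MCF7 cells (Homo sapiens) for antiproliferative activity, read by sulforhodamine B assay, with a stated time of 48 h, tested at 50 uM; a lower number here means less inhibition, a higher number more inhibition at the concentration tested (going by the name of the read-out). Compound 3 stands second highest of the three numbers; its nearest neighbour is compound 1, from which it is separated only by a number 0.4 percentage points lower from compound 1 to compound 3 (within the scatter), within the scatter, while a number 24.8 percentage points higher from compound 2 to compound 3 (beyond the scatter) sets it apart from compound 2 beyond the scatter.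

Compound 4 `CC1=CC[C@H](C(C)C)c2cc(C)c(OC(=O)c3cccc([N+](=O)[O-])c3)cc21` differs from compound 3 by 3-nitrophenyl in place of 4-chlorophenyl on a carbonyl carbon. The two steps that bear on this exchange sit on the same carbonyl carbon: a number 25.2 percentage points lower from compound 1 to compound 2 (beyond the scatter) and a number 24.8 percentage points higher from compound 2 to compound 3 (beyond the scatter). In both, the 3-methylphenyl compound 2 sits below the 4-methoxyphenyl compound 1 and the 4-chlorophenyl compound 3. Within the data shown here, a nitrophenyl group has no measured precedent here, so the effect of the two entering acceptors is unknown. Given that the only other 3-substituted phenyl, compound 2, fell by a number 25.2 percentage points lower from compound 1 to compound 2 (beyond the scatter), a modest drop is expected for compound 4, namely a number 17.7 percentage points lower from compound 3 to compound 4 (beyond the scatter), with wide uncertainty. Compound 4 is thus estimated at 62%, in the range 38% to 86%.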

Compound 4, a percentage reported as inhibition, at one concentration (the size of the read-out at that concentration, not a potency): 29.3%
Compound 4: the middle estimate sits 32.7 percentage points above what was measured; the measured number lies below the stated range.
By their numbers in this assay, from the lowest: compound 4; then compound 2; then compounds 3 and 1 (each within the scatter of the next).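

In this assay, among these compounds, the aryl group on this carbonyl carbon can cost far more than the earlier compounds showed: a number 50.4 percentage points lower from compound 3 to compound 4 (beyond the scatter) and a number 50.8 percentage points lower from compound 1 to compound 4 (beyond the scatter) are both large, so the 3-nitrophenyl ester does not stay with the 4-chlorophenyl and 4-methoxyphenyl esters. The 3-methylphenyl and 3-nitrophenyl esters also part, with a number 25.6 percentage points lower from compound 2 to compound 4 (beyond the scatter) on exchange of methyl for nitro, so among these two compounds a 3-substituted phenyl does not carry one fixed level. Nothing available accounts for these falls.

As far as these compounds go, whether the loss follows the nitro group or its place on the phenyl stays open, and a 4-nitrophenyl or 3-chlorophenyl ester would separate the two. The compounds shown also do not tell how an amine or a carboxylic acid on the same phenyl would read in this assay.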